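Nitro in place of trifluoromethyl: expecting compound 3

A few compounds are considered here, and "the series" means these few. Any claim that something is new, unique, unknown or untested is made for them only; others in the source may bear on it.

Compound 1 `FC(F)(F)c1nc2cc(Cl)c(Cl)cc2n1Cc1ccccc1`: 8700 nM
Compound 2 `FC(F)(F)c1cccc(Cn2c(C(F)(F)F)nc3cc(Cl)c(Cl)cc32)c1`: 68000 nM

In a functional assay on MCF7 cells (Homo sapiens) for cytotoxicity, read by MTT assay, with a stated time of 48 h (a lower number here means a stronger inhibitor of growth, a higher number a weaker inhibitor of growth), compound 2 gives 68000 nM, the higher of the two numbers, and its gap to compound 1 lies beyond the scatter. Compound 3 `O=[N+]([O-])c1cccc(Cn2c(C(F)(F)F)nc3cc(Cl)c(Cl)cc32)c1` has not yet been measured. It alters compound 2 at the trifluoromethyl group: nitro in place of trifluoromethyl on an aromatic carbon. In words, this is nitro in place of trifluoromethyl on an aromatic carbon.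

Among the compounds with values here, no measured step involves nitro, so the evidence is indirect. Within the data shown here, one step bears on the change: a 7.8-fold higher number from compound 1 to compound 2 (0.89 log units; beyond the scatter). That modest rise came with trifluoromethyl in place of hydrogen on an aromatic carbon, so the same carbon is at issue here. Compound 3 loses the trifluoromethyl group but does not return to hydrogen, so only part of that rise is expected to reverse. The expected change is a 1.9-fold lower number from compound 2 to compound 3 (0.28 log units; within the scatter), a small move towards a lower number, near the edge of the scatter. For compound 3 the estimated value is 36000 nM, with an expected range of 11000 nM to 110000 nM.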

Compound 3, concentration for 50% growth inhibition: 60000 nM
The estimate for compound 3 lay 1.7-fold (0.22 log units) below the measured number; the range from low to high includes it.
By their numbers in this assay, from the lowest: compound 1; then compounds 3 and 2 (each within the scatter of the next).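

In this assay, nitro in place of trifluoromethyl on this aromatic carbon leaves the number essentially unchanged (a 1.1-fold lower number from compound 2 to compound 3 (0.05 log units; within the scatter)), so the two groups cannot be told apart here, although nitro brings hydrogen-bond acceptors that trifluoromethyl lacks. Set against hydrogen, nitro gives a step beyond the scatter (a 6.9-fold higher number from compound 1 to compound 3 (0.84 log units; beyond the scatter)), and trifluoromethyl does the same (a 7.8-fold higher number from compound 1 to compound 2 (0.89 log units; beyond the scatter)), so among these three compounds the weaker growth inhibition is not tied to trifluoromethyl alone but appears with both groups tried at this carbon. No measurement accompanying these numbers shows what the two groups have in common that could account for this, and the shift from hydrogen remains a description, not an explanation.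

The compounds shown leave open whether any group on this carbon can match or improve on hydrogen, for instance an amine or a carboxylic acid, which differ in kind from both groups tested. They also leave open whether trifluoromethyl or nitro would give similar numbers on another carbon of the same ring, since both sit at a single place in this series.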